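This account rests on a few compounds, and the source may have more. Where it says the series, first, only, none or still open, it means among the compounds named here.

For the measured compounds named here, in an ADME assay on MRC5 cells (Homo sapiens) for cytotoxicity, read by fluorescence, with a stated time of 72 h (on this read-out higher numbers stand for weaker inhibition and lower numbers for stronger inhibition), three compounds have numbers so far. Compound 1 (`O=[N+]([O-])c1cnc2n1CC(COc1ccc(OC(F)(F)F)cc1)O2`) gives 31000 nM, compound 2 (`O=[N+]([O-])c1cn2c(n1)OC(COc1ccc(-c3ccc(OC(F)(F)F)cc3)cn1)C2`) gives 47000 nM, and compound 3 (`CC1(COc2ccc(OC(F)(F)F)cc2)Cn2c(Br)cnc2O1`) gives 26000 nM. These three values lie within the scatter of one another, so compound 3 stands level with the other two. Compound 4 (`CC1(COc2ccc(OC(F)(F)F)cc2)Cn2c(S(C)(=O)=O)cnc2O1`) follows from compound 3 by one change: methylsulfonyl in place of bromo on an aromatic carbon. Going by the values given here, no measured pair shows what such a change does in this assay, so only the close grouping of the three values offers guidance. The expected shift is small and upward, an estimated 1.5-fold higher number from compound 3 to compound 4 (0.16 log units; within the scatter), and none beyond the scatter is expected. For compound 4 the estimated value is 38000 nM, with an expected range from 15000 nM to 90000 nM.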

Compound 4, half-maximal inhibitory concentration: > 64000 nM
Compound 4: no number, only a limit; the forecaster's own chance of this, stated with the estimate: 20%; middle value at least 1.6-fold (0.22 log units) away from the limit.
By their numbers in this assay, from the lowest: compounds 3, 1 and 2 (each within the scatter of the next). At a limit, above all of these: compound 4.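

In this assay methylsulfonyl in place of bromo on an aromatic carbon, next to the ring nitrogen, gives an at least 2.4-fold higher number from compound 3 to compound 4 (0.39 log units; beyond the scatter) and is the only change shown to move this read-out beyond the scatter. The earlier compounds shown here, all within the scatter of one another, gave no sign of this sensitivity at this position. Compound 4 has no number, only a limit of the assay: the limit of > 64000 nM in this assay, at which 1 of the 4 values shown sits.

On these data alone, the full size of the step therefore stays unknown. As far as these compounds go, it also remains open whether other groups at this position, such as an amine or a carboxylic acid, would shift the value in the same way.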